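Methoxy addition on the acetyl member of the series

This account rests on a few compounds, and the source may have more. Where it says the series, first, only, none or still open, it means among the compounds named here.

Three compounds of this series have so far been run in a functional assay on PC-3 cells (Homo sapiens) for inhibition, read by sulforhodamine B assay, with a stated time of 48 h; a higher number here means a weaker inhibitor of growth, a lower number a stronger inhibitor of growth. Compound 1 `C=C(C)[C@@H]1CC=C(Cn2cc(COc3ccc(C4NC(=O)NC(C)=C4C(=O)OCC)cc3)nn2)CC1` gives 92200 nM. Compound 2 `C=C(C)[C@@H]1CC=C(Cn2cc(COc3ccc(C4NC(=O)NC(C)=C4C(=O)OCC)cc3OC)nn2)CC1` carries a methoxy group on an aromatic carbon where hydrogen stands in the first member; in this assay compound 2 gives 54400 nM, and that change is a 1.7-fold lower number from compound 1 to compound 2 (0.23 log units; within the scatter). Compound 3 `C=C(C)[C@@H]1CC=C(Cn2cc(COc3ccc(C4NC(=O)NC(C)=C4C(C)=O)cc3)nn2)CC1`, with a methyl in place of the ethoxy on the carbonyl carbon, gives 49300 nM; that change is a 1.9-fold lower number from compound 1 to compound 3 (0.27 log units; within the scatter). Compound 3 thus has the lowest of the three numbers, but the values of compound 2 and compound 3 sit so close together that nothing separates them, and the distance to compound 1 is also within the scatter.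

Compound 4 `C=C(C)[C@@H]1CC=C(Cn2cc(COc3ccc(C4NC(=O)NC(C)=C4C(C)=O)cc3OC)nn2)CC1` is the next member: it differs from compound 3 by methoxy in place of hydrogen on an aromatic carbon. Going by the values given here, the one measured step that bears on this change is a 1.7-fold lower number from compound 1 to compound 2 (0.23 log units; within the scatter), made on the ethyl ester member, and it stayed within the scatter. Among the compounds with values here, no second example of this change exists, so a step of the same kind, a small move toward a lower number or none beyond the scatter, is expected in this assay. On that basis compound 4 is estimated at 33000 nM, with a range from 13000 nM to 85000 nM. The expected step is a 1.5-fold lower number from compound 3 to compound 4 (0.17 log units; within the scatter).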

Compound 4, concentration for total growth inhibition: 85700 nM
Compound 4: middle estimate off by 2.6-fold (0.41 log units), on the low side, outside the stated range (above it).
By their numbers in this assay, from the lowest: compounds 3, 2, 4 and 1 (each within the scatter of the next).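

Notes on the methoxy change: in this assay the methoxy in place of hydrogen, ortho to a large group and meta to a large group, gives a 1.7-fold higher number from compound 3 to compound 4 (0.24 log units; within the scatter) on the acetyl member, so the step seen on the ethyl ester member does not carry over in direction, and although each step alone stays within the scatter, the gap between them does not: the same change on two cores in this assay, a 1.7-fold lower number (0.23 log units; within the scatter) from compound 1 to compound 2 and a 1.7-fold higher number (0.24 log units; within the scatter) from compound 3 to compound 4, 2.9-fold (0.47 log units) apart, beyond the scatter of two such steps

Read from the other side of the same four compounds, the methyl in place of ethoxy on the carbonyl carbon gives a 1.6-fold higher number from compound 2 to compound 4 (0.20 log units; within the scatter) on the methoxy-bearing members and likewise fails to match its counterpart on the members without methoxy: the same change on two cores in this assay, a 1.9-fold lower number (0.27 log units; within the scatter) from compound 1 to compound 3 and a 1.6-fold higher number (0.20 log units; within the scatter) from compound 2 to compound 4, 2.9-fold (0.47 log units) apart, beyond the scatter of two such steps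

Within these four compounds the two changes therefore do not add up, and the outcome at the aromatic carbon depends on what stands on the carbonyl carbon.

Going by these compounds, this interaction rests on a single set of four compounds, each step of which lies within the scatter, so its reproducibility remains open. Also open, on these data alone, is whether a hydroxyl or a fluorine at this aromatic carbon, or an amine in place of the methyl on the carbonyl carbon, would show the same dependence.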